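The source may report more compounds than this note shows. Statements on the series, on what has been measured and on what is new or still open speak of the compounds shown alone.

Of the compounds shown here, two sharing the same core have so far been tested, and they differ only in one group on an aromatic carbon. Compound 1 `CC(C)(C)c1ccc(OCC2CCN(CC3CC3)CC2)cc1` carries a tert-butyl group there; in an assay on isolated protein for binding affinity to Sigma non-opioid intracellular receptor 1 (Mus musculus) (on this read-out higher numbers stand for weaker inhibition and lower numbers for stronger inhibition), compound 1 gives 14 nM. Compound 2 `CS(=O)(=O)c1ccc(OCC2CCN(CC3CC3)CC2)cc1` carries a methylsulfonyl group instead; in this assay compound 2 gives 53 nM, which is the highest of the two numbers shown, the only neighbour being compound 1. Within the data shown here, the single step that connects them is a 3.8-fold higher number from compound 1 to compound 2 (0.58 log units; beyond the scatter).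

The next compound, compound 3 `COc1ccc(-c2ccc(OCC3CCN(CC4CC4)CC3)cc2)cc1`, differs from compound 2 in the same place: 4-methoxyphenyl in place of methylsulfonyl on an aromatic carbon. Among the measured compounds shown here, the only step measured so far bears on this change in an indirect way: putting methylsulfonyl in place of tert-butyl raised the number, so taking methylsulfonyl away again and putting a large group in its place is expected to lower it. Because of the step of a 3.8-fold higher number from compound 1 to compound 2 (0.58 log units; beyond the scatter), the expectation is a step of about a 3.5-fold lower number from compound 2 to compound 3 (0.55 log units; beyond the scatter) in this assay. Compound 3 is therefore estimated at 15 nM, within a range from 4 nM to 60 nM.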

Compound 3, inhibition constant: 218 nM
Compound 3: middle estimate off by 15-fold (1.16 log units), on the low side, and the stated range ends below it.
By their numbers in this assay, from the lowest: compound 1; then compound 2; then compound 3.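

In this assay, 4-methoxyphenyl in place of methylsulfonyl makes binding weaker rather than stronger (a 4.1-fold higher number from compound 2 to compound 3 (0.61 log units; beyond the scatter)), and the gap to the tert-butyl compound is larger still (a 16-fold higher number from compound 1 to compound 3 (1.19 log units; beyond the scatter)). The earlier step therefore did not mean that any replacement for methylsulfonyl would recover binding: what matters is which group enters, and among these three compounds the tert-butyl group gives the lowest number, while 4-methoxyphenyl, the only one of the three groups that brings its own aromatic ring, gives the highest. No measurement here explains why this group weakens binding.

On these data alone, a plain phenyl group at this place would help separate the effect of the added ring from that of the methoxy group on it, and that comparison remains open. As far as these compounds go, it is also open how an amine, a carboxylic acid or a small alkyl group such as methyl would compare with tert-butyl on this same aromatic carbon, and whether any group here can give a lower number than compound 1.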